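A few compounds are considered here, and "the series" means these few. Any claim that something is new, unique, unknown or untested is made for them only; others in the source may bear on it.

Measured so far in a functional assay on PANC-1 cells (Homo sapiens) for cytotoxicity, read by MTT assay, with a stated time of 72 h; a lower number here means a stronger inhibitor, a higher number a weaker inhibitor:
compound 1 `COC(=O)c1ccc(NC2=CC(=O)c3ncncc3C2=O)cc1` gives 1100 nM;
compound 2 `O=C1C(Nc2ccc(-c3ccccc3)cc2)=CC(=O)c2ncncc21` gives 400 nM;
compound 3 `CCc1ccc(-c2ccc(NC3=CC(=O)c4ncncc4C3=O)cc2)cc1` gives 1200 nM.

Compound 3 carries the highest of the three numbers, though its gap to compound 1 lies within the scatter, whereas a 3.0-fold higher number from compound 2 to compound 3 (0.48 log units; beyond the scatter). Compound 4 `CCOC(=O)c1ccc(NC2=CC(=O)c3ncncc3C2=O)cc1` is reached from compound 3 by ethoxycarbonyl in place of 4-ethylphenyl on an aromatic carbon. The measured step that bears most on this change runs between compound 1 and compound 3, where the difference was a 1.1-fold higher number from compound 1 to compound 3 (0.04 log units; within the scatter), since compound 4 resembles compound 1 apart from one more carbon in the ester chain. The present change largely reverses that step, so the expected movement is a 1.2-fold lower number from compound 3 to compound 4 (0.08 log units; within the scatter), that is none beyond the scatter. Compound 4 is therefore estimated at 1000 nM, with a range from 400 nM to 2500 nM.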

Compound 4, half-maximal inhibitory concentration: 1600 nM
Beside the measured number, compound 4's estimate is 1.6-fold (0.20 log units) below it; the measured number falls inside the stated range.
By their numbers in this assay, from the lowest: compound 2; then compounds 1, 3 and 4 (each within the scatter of the next).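

In this assay, ethoxycarbonyl in place of 4-ethylphenyl gives a number that cannot be told apart from the earlier one (a 1.3-fold higher number from compound 3 to compound 4 (0.12 log units; within the scatter)), and one more carbon in the ester chain also stays within the scatter (a 1.5-fold higher number from compound 1 to compound 4 (0.16 log units; within the scatter)). Phenyl at this position remains clearly separate from ethoxycarbonyl (a 4.0-fold higher number from compound 2 to compound 4 (0.60 log units; beyond the scatter)), so a ring at this position does not by itself set the number. Nothing available explains these results. On these data alone, whether a carboxylic acid, an amide or a much longer ester chain would fit with these numbers stays open.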